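Aromatic Bromo to Methyl in a Propargyl Amide Series

This account rests on a few compounds, and the source may have more. Where it says the series, first, only, none or still open, it means among the compounds named here.

For the measured compounds named here, compound 1 `C#CCNC(=O)/C(C)=C(\C)c1ccc(Br)cc1` gives 18.4 mg/kg in a functional assay on the whole organism (strain Icem-CET (SPF Caw)) for inhibition, with Mus musculus as the target, with a stated time of 30 min (a higher number here means that more compound is needed for the effect, a lower number that less compound is needed), the highest of the two numbers measured so far. Going by the values given here, compound 2 `C/C(C(=O)NC1CC1)=C(/C)c1ccc(Br)cc1` gives 8.2 mg/kg in this assay, and the one measured step is a 2.2-fold lower number from compound 1 to compound 2 (0.35 log units; beyond the scatter). Compound 3 `C#CCNC(=O)/C(C)=C(\C)c1ccc(C)cc1` differs from compound 1 by methyl in place of bromo on an aromatic carbon. That step touches only the substituent on the amide nitrogen, not the aromatic ring, so nothing measured bears on the present change. The expected step is none beyond the scatter. Compound 3 is therefore expected to give 18 mg/kg in this assay, ranging from 8 mg/kg to 40 mg/kg, an expected step of a 1.0-fold lower number from compound 1 to compound 3 (0.01 log units; within the scatter).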

Compound 3, dose for half-maximal effect: 86.4 mg/kg
Estimate against measurement, compound 3: 4.8-fold (0.68 log units) below; the measured number lies above the stated range.
By their numbers in this assay, from the lowest: compound 2; then compound 1; then compound 3.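

The ring position para to a large group is not silent: with the propargyl amide held fixed, methyl in place of bromo gives a 4.7-fold higher number from compound 1 to compound 3 (0.67 log units; beyond the scatter) in this assay. Bromo and methyl each count one heavy atom, with no ring, hydrogen-bond donor, acceptor or net charge, so these counts do not separate the two groups. No measurement shown here accounts for the step. On these data alone, whether the same step holds on the cyclopropyl amide of compound 2 remains open. So does the standing of chloro, fluoro or methoxy at this position.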